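This account rests on a few compounds, and the source may have more. Where it says the series, first, only, none or still open, it means among the compounds named here.

Working notes on the series. Among the compounds with values here, in an assay on membranes from frontal cortex for displacement of a labelled ligand from Adrenergic receptor alpha-1 (Rattus norvegicus), read by scintillation counting, with a stated time of 45 min (a lower number here means a stronger inhibitor, a higher number a weaker inhibitor), compound 1, `CCC1(CCCCN2CCN(c3ccccc3Cl)CC2)C(=O)Nc2ccccc21`, gives 64 nM, the lower of the two numbers measured so far. Compound 2, `CCC1(CCCCN2CCN(c3cccc(Cl)c3)CC2)C(=O)Nc2cc(F)c(Cl)cc21`, gives 117 nM in this assay, and the gap between compound 1 and compound 2 lies within the scatter, so no order between them can be read from these two values. Within the data shown here, compound 2 also differs from compound 1 in more than one place, so no single step can be drawn from it.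

Compound 3, `CCC1(CCCCN2CCN(c3ccc(F)cc3)CC2)C(=O)Nc2ccccc21`, is not yet measured. It differs from compound 1 in one place: 4-fluorophenyl in place of 2-chlorophenyl on an amine nitrogen in a ring. Among the measured compounds shown here, no measured pair isolates such a change, so there is no step to lean on. The expectation is that the step from compound 1 to compound 3 stays close to the scatter, with a slight lean toward a higher number, a 1.6-fold higher number from compound 1 to compound 3 (0.19 log units; within the scatter). For compound 3 the estimate in this assay is 100 nM, with a range from 30 nM to 350 nM.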

Compound 3, inhibition constant: 39 nM
Compound 3: middle estimate off by 2.6-fold (0.41 log units), on the high side; the range from low to high includes it.
By their numbers in this assay, from the lowest: compounds 3, 1 and 2 (each within the scatter of the next, the first and the last beyond it).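

Within the data shown here, this is the first pair that differs in one place. In this assay, 4-fluorophenyl in place of 2-chlorophenyl on an amine nitrogen in a ring gives a 1.6-fold lower number from compound 1 to compound 3 (0.22 log units; within the scatter) and so does not separate the two groups at this position. The swap alters both the halogen and its place on the phenyl ring, so the step cannot be divided between those two alterations. Nothing at hand bears on why the two groups read alike.

The compounds shown leave open how a plain phenyl, 2-fluorophenyl or 4-chlorophenyl would read on this nitrogen, which would part the halogen from its place on the ring. They also leave open whether the same holds with a shorter chain linking this ring to the shared core.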